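A few compounds are considered here, and "the series" means these few. Any claim that something is new, unique, unknown or untested is made for them only; others in the source may bear on it.

Working notes on the series. Two compounds carry measured numbers in a functional assay on A20 cells (Mus musculus) for inhibition, with stated times of 1 h, 16 h and 24 h (a higher number here means a weaker inhibitor, a lower number a stronger inhibitor), so far. Compound 1 `N#CCNC(=O)[C@@H]1C[C@@H](S(=O)(=O)c2ccccc2Cl)C[C@H]1C(=O)N1CCOCC1` gives 3 nM. Compound 2 `CC1CCN(C(=O)[C@@H]2C[C@H](S(=O)(=O)c3ccccc3)C[C@H]2C(=O)NC2(C#N)CC2)CC1` gives 2 nM; this is the smaller of the two recorded numbers, with compound 1 nearest, but the gap between them lies within the scatter, so no order between compound 1 and compound 2 can be drawn from these two values alone.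

Compound 3 `N#CC1(NC(=O)[C@@H]2C[C@@H](S(=O)(=O)c3ccccc3)C[C@H]2C(=O)N2CCCC2)CC1` is the next compound to go into this assay. The change from compound 2 to compound 3 is pyrrolidin-1-yl in place of 4-methylpiperidin-1-yl on a carbonyl carbon. For the measured compounds named here, no step between two measured compounds isolates a change at this carbonyl, so nothing measured speaks directly to its size. The two measured compounds differ from each other in several places yet give numbers within the scatter of one another, which gives no hint of a large swing. The step from compound 2 to compound 3 is therefore expected to be small, a 1.5-fold higher number from compound 2 to compound 3 (0.18 log units; within the scatter), not beyond the scatter in either direction. Compound 3 is estimated at 3 nM, with a range from 1 nM to 10 nM.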

Compound 3, half-maximal inhibitory concentration: 29 nM
Compound 3: the middle estimate sits 9.7-fold (0.99 log units) below what was measured, outside the stated range (above it).
By their numbers in this assay, from the lowest: compounds 2 and 1 (each within the scatter of the next); then compound 3.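

In this assay, for the compounds shown here, the group on this carbonyl carbon turns out to matter: pyrrolidin-1-yl in place of 4-methylpiperidin-1-yl gives a 15-fold higher number from compound 2 to compound 3 (1.16 log units; beyond the scatter) in the first step that isolates one place. The number therefore moves beyond the scatter on a change from a six-membered ring of 7 heavy atoms to a five-membered ring of 5 heavy atoms, although neither group has a hydrogen-bond donor, a hydrogen-bond acceptor or a net charge. No measurement at hand accounts for the size of this step, so its origin remains unassigned.

This single step does not separate the change in ring size from the loss of the methyl group, and an unsubstituted piperidin-1-yl on the same carbonyl carbon would be needed to divide the two. Also open, going by these compounds, is how a seven-membered azepan-1-yl or an open-chain diethylamino group would read against these two groups at this position.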